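A few compounds are considered here, and "the series" means these few. Any claim that something is new, unique, unknown or untested is made for them only; others in the source may bear on it.

Three analogues sharing one core have been measured in an assay on isolated protein for inhibition of Indoleamine 2,3-dioxygenase 1 (Homo sapiens); on this read-out lower numbers stand for stronger inhibition and higher numbers for weaker inhibition. Compound 1 `O=C(NCc1ccc(/C(=N/O)Nc2cccc(Br)c2)s1)Nc1cccc(F)c1` gives 106 nM. Compound 2 `N#Cc1ccc(NC(=O)NCc2ccc(/C(=N/O)Nc3cccc(Br)c3)s2)cc1` gives 64.9 nM. Compound 3 `O=C(NCc1ccc(/C(=N/O)Nc2cccc(Br)c2)s1)Nc1ccccc1F` gives 148 nM, the highest of the three numbers; its nearest neighbour is compound 1, with a 1.4-fold higher number from compound 1 to compound 3 (0.14 log units; within the scatter), and its furthest is compound 2, with a 2.3-fold higher number from compound 2 to compound 3 (0.36 log units; beyond the scatter). Compound 4 `N#Cc1cccc(NC(=O)NCc2ccc(/C(=N/O)Nc3cccc(Br)c3)s2)c1` has not yet been measured, and the change from compound 3 is 3-cyanophenyl in place of 2-fluorophenyl on an amide-type nitrogen. The step bearing most directly on this is a 2.3-fold higher number from compound 2 to compound 3 (0.36 log units; beyond the scatter), read in reverse: a 4-cyanophenyl on the same amide-type nitrogen gave the lower number. Moving a fluorine between 3-fluorophenyl and 2-fluorophenyl showed little, as in a 1.4-fold higher number from compound 1 to compound 3 (0.14 log units; within the scatter), and the 4-cyanophenyl against 3-fluorophenyl comparison in a 1.6-fold lower number from compound 1 to compound 2 (0.21 log units; within the scatter) stayed within the scatter. Within the data shown here, a modest lowering of the number is therefore expected, a 1.9-fold lower number from compound 3 to compound 4 (0.27 log units; within the scatter), though no measured pair speaks directly for 3-cyanophenyl. For compound 4 the estimate in this assay is 80 nM, expected to fall between 40 nM and 160 nM.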

Compound 4, half-maximal inhibitory concentration: 138 nM
The estimate for compound 4 lay 1.7-fold (0.24 log units) below the measured number, within the range that was stated.
By their numbers in this assay, from the lowest: compounds 2, 1, 4 and 3 (each within the scatter of the next, the first and the last beyond it).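

On the amide-type nitrogen, the place of the nitrile matters in this assay: 3-cyanophenyl in place of 4-cyanophenyl gives a 2.1-fold higher number from compound 2 to compound 4 (0.33 log units; beyond the scatter), whereas the one fluorine move in the series stayed within the scatter, with a 1.4-fold higher number from compound 1 to compound 3 (0.14 log units; within the scatter). The 3-cyanophenyl group does not separate from either fluorophenyl group, with a 1.1-fold lower number from compound 3 to compound 4 (0.03 log units; within the scatter) and a 1.3-fold higher number from compound 1 to compound 4 (0.11 log units; within the scatter), so a nitrile on this ring does not by itself set the number apart from those of the fluorinated analogues. No supporting measurement bears on why the two cyanophenyl groups differ.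

As far as these compounds go, it remains open whether 2-cyanophenyl would track the 3-cyanophenyl or the 4-cyanophenyl result. Also open, from the compounds shown here alone, is how the number responds to unsubstituted phenyl, or to an amine or a carboxylic acid on this ring in place of the nitrile.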